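The source may hold more compounds than are shown below. What is called first, only, known or untested is meant among the compounds shown, and "the series" means these compounds.

In a functional assay on MCF7 cells (Homo sapiens) for antiproliferative activity, read by MTT assay, with a stated time of 72 h (on this read-out lower numbers stand for stronger inhibition and higher numbers for weaker inhibition), three compounds built on one shared core have been measured, and a fourth awaits its number. Compound 1 `CCCSc1nc(N/N=C(\C)c2ccc(OC)cc2)c2nnn(Cc3ccccc3)c2n1` carries a methoxy group on its outer aromatic ring. In this assay compound 1 gives > 64000 nM, which is a limit of the assay and not a number, so on the numbers shown compound 1 stands at the limit of > 64000 nM in this assay, at which 1 of the 3 values shown sits, and no more can be said of it. Compound 2 `C#CCSc1nc(N/N=C(\C)c2ccccc2O)c2nnn(Cc3ccccc3)c2n1` gives 11300 nM in this assay. Compound 3 `CCCSc1nc(N/N=C(\C)c2ccccc2O)c2nnn(Cc3ccc(O)cc3)c2n1` gives 9520 nM in this assay. The values of compound 2 and compound 3 lie within the usual scatter of each other.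

Compound 4 `CCCSc1nc(N/N=C(\C)c2ccccc2)c2nnn(Cc3ccccc3)c2n1` has not been measured. It differs from compound 1 at a single place: hydrogen in place of methoxy on an aromatic carbon. Going by the values given here, no measured pair shows this change, so the expectation rests only on where compound 1 sits. The step from compound 1 to compound 4 is expected to be an at least 1.4-fold lower number from compound 1 to compound 4 (0.15 log units; that floor lies within the scatter), meaning no change beyond the scatter, with a fair chance that only a limit is reported again. Compound 4 is therefore expected to give about 45000 nM in this assay, within a range from 15000 nM to 130000 nM.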

Compound 4, half-maximal inhibitory concentration: 32100 nM
Compound 4: middle estimate off by 1.4-fold (0.15 log units), on the high side, and the stated range covers the measured number.
By their numbers in this assay, from the lowest: compounds 3 and 2 (each within the scatter of the next); then compound 4. At a limit, above all of these: compound 1.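

In this assay, hydrogen in place of methoxy on this aromatic carbon, para to a large group, gives an at least 1.9-fold lower number from compound 1 to compound 4 (0.29 log units; that floor lies within the scatter), the only reading of this change among the compounds shown. With the plain phenyl ring, compound 4 returns a true number, and this gives the position a measured starting point that compound 1, which has only a limit of the assay, could not provide. The step is only a floor that does not itself clear the usual scatter, and the real difference could be larger, because compound 1 stands at a limit and not at a number: the limit of > 64000 nM in this assay, at which 1 of the 4 values shown sits.

Only methoxy and hydrogen are shown on this carbon, so it remains open how an amine, a chlorine atom or a carboxylic acid would read there. Compounds 2 and 3 differ from compound 4 in more than one place, so they cannot tell whether this change would give a similar step with other groups elsewhere on the shared core.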